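Swapping the Ethoxyphenyl Cap for a Dialkylphenyl

The source may report more compounds than this note shows. Statements on the series, on what has been measured and on what is new or still open speak of the compounds shown alone.

Compound 3 `CCOc1ccc(-n2nncc2CN2C(=O)C3(C(C#N)=C(N)Oc4c(N)cc5nc6ccccc6nc5c43)c3ccccc32)cc1` is the only one of the three measured compounds with an actual number: in a functional assay on MCF7 cells (Homo sapiens) for antiproliferative activity, read by MTT assay, with a stated time of 48 h (on this read-out lower numbers stand for stronger inhibition and higher numbers for weaker inhibition), compound 3 gives 26800 nM. Compound 1 `Cc1ccccc1-n1nncc1CN1C(=O)C2(C(C#N)=C(N)Oc3c(N)cc4nc5ccccc5nc4c32)c2ccccc21` reaches only a limit of this assay, > 50000 nM. Compound 2 `N#CC1=C(N)Oc2c(N)cc3nc4ccccc4nc3c2C12C(=O)N(Cc1cnnn1-c1ccc(F)cc1)c1ccccc12` likewise shows a limit, > 50000 nM. Compound 4 `CCc1cccc(C)c1-n1nncc1CN1C(=O)C2(C(C#N)=C(N)Oc3c(N)cc4nc5ccccc5nc4c32)c2ccccc21` differs from compound 3 in one place: 2-ethyl-6-methylphenyl in place of 4-ethoxyphenyl on an aromatic nitrogen. Among the compounds with values here, two measured steps bear on this change: an at least 1.8-fold lower number from compound 1 to compound 3 (0.27 log units; that floor lies within the scatter) and an at least 1.8-fold lower number from compound 2 to compound 3 (0.27 log units; that floor lies within the scatter), where the limit of > 50000 nM in this assay, at which 2 of the 3 values shown sit, sets the floor of each. Compound 4 resembles compound 1 in carrying a phenyl ring with no hydrogen-bond acceptor. For compound 4 a step back toward the limit is therefore expected, of size a 1.7-fold higher number from compound 3 to compound 4 (0.23 log units; within the scatter). The estimated value for compound 4 is 45000 nM, within a range from 20000 nM to 100000 nM.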

Compound 4, half-maximal inhibitory concentration: > 50000 nM
Compound 4: no number, only a limit (the forecaster's own chance of this, stated with the estimate: 55%); middle value at least 1.1-fold (0.04 log units) away from the limit.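

From the compounds shown here alone, putting 2-ethyl-6-methylphenyl in place of 4-ethoxyphenyl on the aromatic nitrogen gives an at least 1.8-fold higher number from compound 3 to compound 4 (0.27 log units; that floor lies within the scatter), so the true size of this step remains unknown. Both groups have the same heavy-atom count, yet only the oxygen-bearing 4-ethoxyphenyl of compound 3 gives a number in this assay. The steps linking compound 1, compound 2 and compound 4 to one another cannot be read: the limit of > 50000 nM in this assay, at which 3 of the 4 values shown sit.

Compound 4 changes both the oxygen and the placement of the ring's groups, leaving open which one matters. A 4-propylphenyl group, which keeps the placement of the ethoxy group but has no oxygen, could help separate the two.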